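The source may hold more compounds than are shown below. What is called first, only, known or untested is meant among the compounds shown, and "the series" means these compounds.

Three compounds sharing one core, differing only in the aromatic group attached to the urea nitrogen, have been tested in an assay on isolated protein for inhibition of Fatty-acid amide hydrolase 1 (Homo sapiens), with a stated time of 60 min; on this read-out lower numbers stand for stronger inhibition and higher numbers for weaker inhibition. Compound 1 `O=C(Nc1cncc2ccccc12)N1CCN(Cc2cccc(Oc3ccc(Cl)cc3)c2)CC1` gives 6.7 nM in this assay. Compound 2 `O=C(Nc1noc2cnccc12)N1CCN(Cc2cccc(Oc3ccc(Cl)cc3)c2)CC1` gives 0.5 nM, and the step of a 13-fold lower number from compound 1 to compound 2 (1.13 log units; beyond the scatter) shows that exchanging this group can move the result a long way. Among the measured compounds shown here, compound 3 `O=C(Nc1cn2ccccc2n1)N1CCN(Cc2cccc(Oc3ccc(Cl)cc3)c2)CC1` reaches only > 10000 nM in this assay, which is a limit of the assay rather than a measured number; it is the one compound sitting at the limit of > 10000 nM in this assay, at which 1 of the 3 values shown sits. On the numbers shown, compound 3 therefore stands far weaker than the other two, as the steps of an at least 1400-fold higher number from compound 1 to compound 3 (3.17 log units; beyond the scatter) and an at least 20000-fold higher number from compound 2 to compound 3 (4.30 log units; beyond the scatter) record.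

Compound 4 `O=C(Nc1ccc2nccn2c1)N1CCN(Cc2cccc(Oc3ccc(Cl)cc3)c2)CC1` is built from the same atoms as compound 3, joined differently: a group of 9 heavy atoms (7 carbon, 2 nitrogen; one five-membered aromatic ring with 2 hetero atoms, one six-membered aromatic ring with 1 hetero atom) in place of a group of 9 heavy atoms (7 carbon, 2 nitrogen; one five-membered aromatic ring with 2 hetero atoms, one six-membered aromatic ring with 1 hetero atom), on an amide-type nitrogen. For the measured compounds named here, no measured step covers this particular rearrangement, so the only guidance is how strongly this assay responds to the group on the urea nitrogen, from small steps to very large ones. Since compound 3 sits at a limit, any measurable number would be an improvement; the expected step is an at least 66-fold lower number from compound 3 to compound 4 (1.82 log units; beyond the scatter). Compound 4 is estimated at 150 nM, with a range from 10 nM to 3000 nM.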

Compound 4, half-maximal inhibitory concentration: 100 nM
Estimate against measurement, compound 4: 1.5-fold (0.18 log units) above; the measured number falls inside the stated range.
By their numbers in this assay, from the lowest: compound 2; then compound 1; then compound 4. At a limit, above all of these: compound 3.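

Keeping the atoms of the group and changing only how they are joined is enough to move the result on the amide-type nitrogen a long way in this assay: the change gives an at least 100-fold lower number from compound 3 to compound 4 (2.00 log units; beyond the scatter), so the atom counts alone do not settle the outcome at this position. As far as these compounds go, the value of compound 3 is a limit of the assay, not a number, so the true size of this step stays unknown: the limit of > 10000 nM in this assay, at which 1 of the 4 values shown sits. The rearrangement restores a measurable result but does not reach the better groups, as a 200-fold higher number from compound 2 to compound 4 (2.30 log units; beyond the scatter) and a 15-fold higher number from compound 1 to compound 4 (1.17 log units; beyond the scatter) show.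

Four compounds cannot tell which feature of the joining matters, and no measured property here explains the difference between compound 3 and compound 4. It also remains open how simpler groups on this nitrogen, such as a single phenyl ring or a single pyridine ring, would compare with the two-ring groups shown, and whether the order seen here would hold with a different shared core.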